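A few compounds are considered here, and "the series" means these few. Any claim that something is new, unique, unknown or untested is made for them only; others in the source may bear on it.

Measured compounds:
compound 1 `Cc1ccc(/C=C2\CCC/C(=C\c3ccc([N+](=O)[O-])cc3)C2=O)cc1` gives 8160 nM
compound 2 `O=C1/C(=C/c2ccc(Cl)cc2)CCC/C1=C\c1ccccc1[N+](=O)[O-]` gives 9380 nM
compound 3 `O=C1/C(=C/c2ccc(Cl)cc2)CCC/C1=C\c1cccc([N+](=O)[O-])c1` gives 9160 nM

These three values come from a functional assay on L1210 cells (Mus musculus) for cytotoxicity, with a stated time of 48 h; on this read-out higher numbers stand for weaker inhibition and lower numbers for stronger inhibition. Compound 1 has the lowest of the three numbers, but its distance to compound 3 and to compound 2 lies within the usual scatter of repeated measurements, so the three compounds cannot be told apart on this read-out, and none of them can be called the most or least active.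

Compound 4 `O=C1/C(=C/c2ccccc2)CCC/C1=C\c1ccc([N+](=O)[O-])cc1` has not yet been measured in this assay. It differs from compound 1 by one change: hydrogen in place of methyl on an aromatic carbon. In other words, hydrogen stands in place of methyl on an aromatic carbon, para to a large group; seen one bond further out, a 4-methylphenyl becomes a phenyl.

Going by the values given here, no step between measured compounds removes a methyl in this way, so there is no direct precedent. The three measured compounds, with different substituents on their two outer rings, all give numbers within the scatter of one another, which suggests that changes of this kind on the outer rings leave the read-out largely unchanged. Compound 4 is therefore expected to show a step of a 1.1-fold higher number from compound 1 to compound 4 (0.04 log units; within the scatter), that is, no step beyond the scatter. The estimate for compound 4 is 9000 nM, with a range from 4500 nM to 18000 nM.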

Compound 4, half-maximal inhibitory concentration: 9800 nM
For compound 4 the middle estimate is 1.1-fold (0.04 log units) below the measured one, and the stated range covers the measured number.
By their numbers in this assay, from the lowest: compounds 1, 3, 2 and 4 (each within the scatter of the next).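

In this assay, going by these compounds alone, the change from 4-methylphenyl to phenyl gives a 1.2-fold higher number from compound 1 to compound 4 (0.08 log units; within the scatter) and so provides the first direct reading of this change, which the earlier compounds, differing from one another in more than one place, could not give. At this position, on an aromatic carbon para to a large group, the methyl and the hydrogen cannot be told apart on this read-out, so in this one pair the methyl makes no measurable difference. No measurement at hand offers an explanation for this result.

Going by these compounds, it remains open whether an amine, a carboxylic acid or a longer chain at this position would shift the number beyond the scatter. On these data alone, it also remains open whether removing the methyl would read the same with other groups on the opposite outer ring.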